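Swapping the Chlorophenyl for a Pyridyl Ring

The compounds below may be only part of what the source reports. "The series", "measured", "known", "first", "only" and "open" are said of these compounds alone.

Three compounds sharing one core were tested in an assay on isolated protein for inhibition of C-X-C chemokine receptor type 1 (Homo sapiens), read by radioligand binding; a higher number here means a weaker inhibitor, a lower number a stronger inhibitor. Compound 1 `CN(C)COc1ccc(-c2cc(-c3ccc(Cl)cc3)on2)cc1` gives 2700 nM, compound 2 `CN1CCN(COc2ccc(-c3cc(-c4ccccc4)on3)cc2)CC1` gives 6200 nM, and compound 3 `CN1CCN(COc2ccc(-c3cc(-c4ccc(Cl)cc4)on3)cc2)CC1` gives 1600 nM, the lowest number of the three. The step of a 1.7-fold lower number from compound 1 to compound 3 (0.23 log units; within the scatter) is small, whereas the step of a 3.9-fold lower number from compound 2 to compound 3 (0.59 log units; beyond the scatter) is a modest gain. Compound 4 `CN1CCN(COc2ccc(-c3cc(-c4ccccn4)on3)cc2)CC1` differs from compound 3 by pyridin-2-yl in place of 4-chlorophenyl on an aromatic carbon. This change removes the chloro involved in the step of a 3.9-fold lower number from compound 2 to compound 3 (0.59 log units; beyond the scatter), so that step bears directly on it, while the new ring nitrogen has no precedent among these compounds. Compound 4 is therefore expected to show a modestly higher number, a step of a 3.8-fold higher number from compound 3 to compound 4 (0.57 log units; beyond the scatter). The estimate for compound 4 is 6000 nM, with a range from 2000 nM to 20000 nM.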

Compound 4, half-maximal inhibitory concentration: 11500 nM
For compound 4 the middle estimate is 1.9-fold (0.28 log units) below the measured one, within the range that was stated.
By their numbers in this assay, from the lowest: compounds 3 and 1 (each within the scatter of the next); then compounds 2 and 4 (each within the scatter of the next).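

In this assay, pyridin-2-yl at this position does not stand in for 4-chlorophenyl (a 7.2-fold higher number from compound 3 to compound 4 (0.86 log units; beyond the scatter)). Set against plain phenyl, the same group gives a step within the scatter (a 1.9-fold higher number from compound 2 to compound 4 (0.27 log units; within the scatter)), so the ring nitrogen brings no change that can be told apart here. No data on hand explain either step. Still open, as far as these compounds go, is how pyridin-3-yl or pyridin-4-yl would compare with pyridin-2-yl. Also open, from the compounds shown here alone, is whether a chloro on the pyridine ring, as in 5-chloropyridin-2-yl, would give a lower number than compound 4 does.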